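The compounds below may be only part of what the source reports. "The series", "measured", "known", "first", "only" and "open" are said of these compounds alone.

Compound 1 `CC(C)c1n[nH]c2c(NCc3ccc(-c4ccccn4)cc3)nc(SCC(O)CN3CCNCC3)nc12` and compound 2 `CC(C)c1n[nH]c2c(NCc3ccc(-c4ccccn4)cc3)nc(SCCNC(=N)N)nc12` share one core and differ only at the thioether side chain. Going by the values given here, in a functional assay on HT cells (Homo sapiens) for antiproliferative activity, read by fluorescence, with a stated time of 72 h (a higher number here means a weaker inhibitor of growth, a lower number a stronger inhibitor of growth), compound 1 gives 332 nM, and compound 2 gives 390 nM; the change a 1.2-fold higher number from compound 1 to compound 2 (0.07 log units; within the scatter) leaves the two indistinguishable, so compound 2 stands level with its only neighbour. Compound 3 `CCC(CO)Sc1nc(NCc2ccc(-c3ccccn3)cc2)c2[nH]nc(C(C)C)c2n1` is not yet measured; it differs from compound 2 by a group of 5 heavy atoms (4 carbon, 1 oxygen; no ring) in place of a group of 6 heavy atoms (3 carbon, 3 nitrogen; no ring), on a sulfur. Among the compounds with values here, the one measured step bears only loosely on this change, since it swapped one nitrogen-rich chain for another. A small drift toward a higher number, a 1.7-fold higher number from compound 2 to compound 3 (0.22 log units; within the scatter), is expected, giving compound 3 an estimated 650 nM within 220 nM to 2000 nM.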

Compound 3, concentration for 50% growth inhibition: 255 nM
The estimate for compound 3 lay 2.5-fold (0.41 log units) above the measured number, within the range that was stated.
By their numbers in this assay, from the lowest: compounds 3, 1 and 2 (each within the scatter of the next).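

In this assay, the side chain on the sulfur can lose all its nitrogen without the number leaving the scatter: a 1.5-fold lower number from compound 2 to compound 3 (0.18 log units; within the scatter) and a 1.3-fold lower number from compound 1 to compound 3 (0.11 log units; within the scatter). Compound 3 thus stands level with compound 1 and compound 2, and 1-(hydroxymethyl)propyl joins two nitrogen-bearing chains as a tolerated group at this place. No available evidence bears on this result. Still open, going by these compounds, is whether a carboxylic acid, a simple amine or a longer alkyl chain on this sulfur would keep the number at this level. Also open, on these data alone, is what happens when the hydroxyl of 1-(hydroxymethyl)propyl is removed.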